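Dimethylamino for Phenoxy: Expecting Compound 4

The compounds below may be only part of what the source reports. "The series", "measured", "known", "first", "only" and "open" are said of these compounds alone.

Of the compounds shown here, three of one series have been measured so far: compound 1 `COc1cc(C)cc(-c2c(-c3ccnc(-c4ccc(C(C)=O)cc4)c3)cnn2CC#N)c1`, compound 2 `COc1cc(C)cc(-c2nn(CC#N)cc2-c2ccc(-c3cccc(C(C)=O)c3)nc2)c1` and compound 3 `Cc1cc(O)cc(-c2nn(CC#N)cc2-c2ccnc(-c3ccc(Oc4ccccc4)cc3)c2)c1`. In a functional assay on SK-MEL-2 cells (Homo sapiens) for cytotoxicity, read by sulforhodamine B assay, with a stated time of 48 h, tested at 0.01 uM (on this read-out lower numbers stand for a stronger effect and higher numbers for a weaker effect at the one concentration tested), compound 1 gives 90%. In this assay compound 2 gives 89%. In this assay compound 3 gives 99%, the highest of the three numbers, though its gaps to compound 1 and to compound 2 both lie within the usual scatter, so no order among the three can be read from them.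

Compound 4 `Cc1cc(O)cc(-c2nn(CC#N)cc2-c2ccnc(-c3ccc(N(C)C)cc3)c2)c1` has not yet been measured. It differs from compound 3 in one place: dimethylamino in place of phenoxy on an aromatic carbon. Among the compounds with values here, no pair of measured compounds differs in a single place, so no measured step offers a guide to this change. All three measured numbers sit close together near the top of the scale; the change is expected to give a number 4 percentage points lower from compound 3 to compound 4 (within the scatter) in this assay, a step not beyond the scatter in either direction. Compound 4 is accordingly estimated to give 95% in this assay, within a range from 82% to 105%.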

Compound 4, a percentage reported as activity, at one concentration (the size of the read-out at that concentration, not a potency): 108%
The estimate for compound 4 lay 13 percentage points below the measured number; measured number outside the range, above it.
By their numbers in this assay, from the lowest: compounds 2, 1, 3 and 4 (each within the scatter of the next, the first and the last beyond it).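

In this assay, within the data shown here, dimethylamino in place of phenoxy on an aromatic carbon, para to a large group, gives a number 9 percentage points higher from compound 3 to compound 4 (within the scatter), the first step that can be read at a single place. It shows that at this position the phenoxy group, with its six-membered aromatic ring, can give way to the smaller dimethylamino group, which has no ring, without a step beyond the scatter at the one concentration tested. Nothing available accounts for the direction or size of this step.

As far as these compounds go, it remains open whether a carboxylic acid, a primary amine or a longer alkoxy chain on this carbon would give a step beyond the scatter. The compounds shown also leave open whether the same exchange would behave alike at higher concentrations, where the read-out may not sit so near the top of the scale.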